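A few compounds are considered here, and "the series" means these few. Any claim that something is new, unique, unknown or untested is made for them only; others in the source may bear on it.

Measured so far, in a functional assay on A2780 cells (Homo sapiens) for antiproliferative activity; a lower number here means a stronger inhibitor of growth, a higher number a weaker inhibitor of growth:
compound 1 `C[C@H]1CC(Cl)=C([Si](C)(C)C)[C@@H](C2CCCCC2)O1` gives 17000 nM;
compound 2 `CC[C@H]1CC(Cl)=C([Si](C)(C)C)[C@@H](C2CCCCC2)O1` gives 16000 nM;
compound 3 `C[Si](C)(C)C1=C(Cl)C[C@H](C2CCCCC2)O[C@@H]1C1CCCCC1` gives 22000 nM.

Compound 3 has the highest of the three numbers in this assay, yet the steps leading to it are a 1.3-fold higher number from compound 1 to compound 3 (0.11 log units; within the scatter) and a 1.4-fold higher number from compound 2 to compound 3 (0.14 log units; within the scatter), both within the scatter, so no order among the three is established. Compound 4 `C[Si](C)(C)C1=C(Cl)C[C@H](Cc2ccccc2)O[C@@H]1C1CCCCC1` is not yet measured; it carries benzyl in place of cyclohexyl on a saturated ring carbon. Within the data shown here, the steps that bear on this change are the two at the same saturated ring carbon, a 1.3-fold higher number from compound 1 to compound 3 (0.11 log units; within the scatter) and a 1.4-fold higher number from compound 2 to compound 3 (0.14 log units; within the scatter), neither beyond the scatter; a 1.1-fold lower number from compound 1 to compound 2 (0.03 log units; within the scatter) elsewhere in the shared core is likewise flat. On this basis no step beyond the scatter is expected in this assay, in either direction. Compound 4 is therefore estimated at 20000 nM, range 8000 nM to 50000 nM. The expected step is a 1.1-fold lower number from compound 3 to compound 4 (0.04 log units; within the scatter).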

Compound 4, concentration for 50% growth inhibition: 34000 nM
For compound 4 the middle estimate is 1.7-fold (0.23 log units) below the measured one; measured number inside the range.
By their numbers in this assay, from the lowest: compounds 2, 1, 3 and 4 (each within the scatter of the next, the first and the last beyond it).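

At this saturated ring carbon next to the ring oxygen, benzyl in place of cyclohexyl leaves this assay flat (a 1.5-fold higher number from compound 3 to compound 4 (0.19 log units; within the scatter)). Against the smaller groups, the one step beyond the scatter is modest (a 2.1-fold higher number from compound 2 to compound 4 (0.33 log units; beyond the scatter)), while the other stays within it (a 2.0-fold higher number from compound 1 to compound 4 (0.30 log units; within the scatter)), so the aromatic ring brings no gain in growth inhibition over the saturated groups shown. No measurement on hand accounts for these numbers. Still open, going by these compounds, is whether an amine or a carboxylic acid on this carbon would give a step beyond the scatter in the direction of a lower number.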